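The source may hold more compounds than are shown below. What is called first, only, known or untested is meant among the compounds shown, and "the series" means these compounds.

Of the compounds shown here, three built on a shared core have been measured in an ADME assay on BHK-21 cells (Mesocricetus auratus) for cytotoxicity, read by MTT assay, with a stated time of 72 h; a higher number here means that more compound is tolerated, a lower number that less compound is tolerated. Compound 1 `NS(=O)(=O)c1ccc(N2N=C(c3ccc(OCc4ccccc4)cc3)CC2c2ccccc2)cc1` gives 80000 nM in this assay. Compound 2 `NS(=O)(=O)c1ccc(N2N=C(c3ccc(OCc4ccccc4)cc3)CC2c2ccc(F)cc2)cc1` gives 60000 nM in this assay, and the step of a 1.3-fold lower number from compound 1 to compound 2 (0.12 log units; within the scatter) is the only measured case of a fluoro entering an aromatic ring. Compound 3 `NS(=O)(=O)c1ccc(N2N=C(c3ccc(Oc4ccccc4)cc3)CC2c2ccccc2)cc1` gives 11000 nM in this assay, the lowest of the three numbers, meaning the least tolerated of the three. The step of a 7.3-fold lower number from compound 1 to compound 3 (0.86 log units; beyond the scatter) accounts for its gap to the highest number, and its value also lies beyond the scatter from that of compound 2.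

Compound 4 `NS(=O)(=O)c1ccc(N2N=C(c3ccc(Oc4ccccc4)cc3)CC2c2ccccc2F)cc1` has not yet been measured. It differs from compound 3 by fluoro in place of hydrogen on an aromatic carbon. Going by the values given here, the only measured step that bears on such a change is a 1.3-fold lower number from compound 1 to compound 2 (0.12 log units; within the scatter), which stayed within the scatter, though there the fluoro did not enter ortho to a large group, a placement untested so far. On that basis the expected step in this assay is a 1.1-fold lower number from compound 3 to compound 4 (0.04 log units; within the scatter), nothing beyond the scatter. Compound 4 is therefore estimated at 10000 nM, with a range from 5000 nM to 22000 nM.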

Compound 4, half-maximal cytotoxic concentration: 32000 nM
Estimate against measurement, compound 4: 3.2-fold (0.51 log units) below; measured number outside the range, above it.
By their numbers in this assay, from the lowest: compound 3; then compounds 4, 2 and 1 (each within the scatter of the next, the first and the last beyond it).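

On the compound 3 core, fluoro in place of hydrogen, ortho to a large group on a six-membered aromatic ring, gives a 2.9-fold higher number from compound 3 to compound 4 (0.46 log units; beyond the scatter) in this assay, so at this place the change moves the number beyond the scatter, towards more compound being tolerated. Going by these compounds alone, this is the first measured case of a fluoro changing the number, and a single fluoro is a very small change: one heavy atom, no ring and no charge. The size and direction of this change therefore do not carry over unchanged from one compound pair to the other: the same change on two cores in this assay, a 1.3-fold lower number (0.12 log units; within the scatter) from compound 1 to compound 2 and a 2.9-fold higher number (0.46 log units; beyond the scatter) from compound 3 to compound 4, 3.9-fold (0.59 log units) apart, beyond the scatter of two such steps.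

The compounds shown leave open whether this difference follows the place of the fluoro or the phenyl in place of benzyl on the oxygen; the two pairs differ in both. As far as these compounds go, whether another group at this place, such as chloro, methoxy or an amine, would shift the number in the same way also remains open.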